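Pyrazole carboxylic acids against BJAB cell proliferation

The compounds below may be only part of what the source reports. "The series", "measured", "known", "first", "only" and "open" are said of these compounds alone.

Measured compounds:
compound 1, `CCSc1sc(-n2nc(C)c(Cc3ccccc3[N+](=O)[O-])c2C(=O)O)nc1-c1ccc(Cl)c(Cl)c1`, 59000 nM
compound 2, `COc1ccc(C)cc1-c1c(C)nn(-c2nc(-c3ccc(Cl)c(Cl)c3)c(SC(C)C)s2)c1C(=O)O`, 9500 nM
compound 3, `COC(=O)c1c(Cc2ccccc2[N+](=O)[O-])c(C)nn1-c1nc(-c2ccc(Cl)c(Cl)c2)cs1`, 377000 nM

In a functional assay on BJAB cells (Homo sapiens) for antiproliferative activity, with a stated time of 4 days (a higher number here means that more compound is needed for the effect, a lower number that less compound is needed), compound 2 gives the lowest of the three numbers with 9500 nM. Compound 1 comes nearest, and its value in this assay of 59000 nM lies beyond the scatter above compound 2. Compound 3 stands furthest, with 377000 nM in this assay, again well beyond the scatter. Compound 2 is therefore the most potent of the measured set.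

The next compound, compound 4, `Cc1nn(-c2nc(-c3ccc(Cl)c(Cl)c3)c(SC(C)C)s2)c(C(=O)O)c1-c1cncnc1`, differs from compound 2 in one place: pyrimidin-5-yl in place of 2-methoxy-5-methylphenyl on an aromatic carbon. Within the data shown here, no pair of measured compounds isolates this exchange, so nothing measured shows its effect directly; the expectation rests on compound 2 alone and on the spread seen across the three compounds. A modest loss is estimated, with the step of a 2.6-fold higher number from compound 2 to compound 4 (0.42 log units; beyond the scatter) in this assay expected to go upward but not by a large margin. Compound 4 is accordingly expected to give about 25000 nM, within a range from 6000 nM to 90000 nM.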

Compound 4, half-maximal effective concentration: 22000 nM
Beside the measured number, compound 4's estimate is 1.1-fold (0.06 log units) above it; the range from low to high includes it.
By their numbers in this assay, from the lowest: compound 2; then compound 4; then compound 1; then compound 3.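

Among these compounds, compound 2 to compound 4 gives the first direct reading of a change at this aromatic carbon, which stands next to the ring atom that bears a carboxy group. In this assay, replacing 2-methoxy-5-methylphenyl with pyrimidin-5-yl gives a 2.3-fold higher number from compound 2 to compound 4 (0.36 log units; beyond the scatter), a modest rise. The position therefore accepts a smaller aromatic ring with two ring nitrogens, and the methoxy and methyl groups are not required for a measurable effect, though the number does rise. Nothing available here accounts for the step.

The exchange alters the ring atoms and removes the methoxy and methyl groups together, so the part that carries the step remains unresolved. As far as these compounds go, how a plain phenyl or a pyridin-3-yl would read at this carbon also stays open.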